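Pyrazole aryl swap: cyanophenyl replaced by pyridinyl

The source may hold more compounds than are shown below. What is called first, only, known or untested is meant among the compounds shown, and "the series" means these compounds.

Compound 1 `Cc1cc(N2CCN([C@@H]3CN[C@H](C(=O)N4CCSC4)C3)CC2)n(-c2ccc(Cl)cc2)n1` and compound 2 `Cc1cc(N2CCN([C@@H]3CN[C@H](C(=O)N4CCSC4)C3)CC2)n(-c2ccc(C#N)cc2)n1` share one core and differ only in the group carried on the pendant phenyl. In an assay on a cell-free system (plasma) for inhibition of Dipeptidyl peptidase 4 (Rattus norvegicus), read by fluorescence, with a stated time of 60 min (a higher number here means a weaker inhibitor, a lower number a stronger inhibitor), compound 1 gives 2.9 nM, while compound 2 gives 13 nM. Going by the values given here, the exchange of chloro for cyano produced a 4.5-fold higher number from compound 1 to compound 2 (0.65 log units; beyond the scatter), so compound 2 carries the higher of the two numbers measured so far.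

Compound 3 `Cc1cc(N2CCN([C@@H]3CN[C@H](C(=O)N4CCSC4)C3)CC2)n(-c2cccnc2)n1` awaits measurement. Its change relative to compound 2 is pyridin-3-yl in place of 4-cyanophenyl on an aromatic nitrogen. Among the compounds with values here, no measured step exchanges the whole aryl for a six-membered ring with one hetero atom; the only step that bears on this position, a 4.5-fold higher number from compound 1 to compound 2 (0.65 log units; beyond the scatter), shows that altering the group here moves this assay by a modest amount. A modest step toward a higher number, or none beyond the scatter, is therefore expected, a 1.5-fold higher number from compound 2 to compound 3 (0.19 log units; within the scatter). The estimate for compound 3 in this assay is 20 nM, with a range from 6 nM to 70 nM.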

Compound 3, half-maximal inhibitory concentration: 0.77 nM
Compound 3: middle estimate off by 26-fold (1.41 log units), on the high side; the whole stated range lies above it.
By their numbers in this assay, from the lowest: compound 3; then compound 1; then compound 2.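

In this assay, replacing the whole aryl group on the aromatic nitrogen gives a larger step than exchanging its substituent: pyridin-3-yl in place of 4-cyanophenyl gives a 17-fold lower number from compound 2 to compound 3 (1.23 log units; beyond the scatter), whereas cyano in place of chloro gives a 4.5-fold higher number from compound 1 to compound 2 (0.65 log units; beyond the scatter). The pyridin-3-yl group also improves on the better of the two phenyl compounds, with a 3.8-fold lower number from compound 1 to compound 3 (0.58 log units; beyond the scatter), so a substituted phenyl is not required here for low-nanomolar inhibition in this set of three compounds. No measured evidence on the series accounts for these steps.

The compounds shown leave open whether the lower number goes with the ring nitrogen or with the loss of the chloro or cyano group. An unsubstituted phenyl would separate these two readings, and pyridin-2-yl or pyridin-4-yl would show whether the ring nitrogen's location matters.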